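Anilino in Place of a Ketone Side Chain on a Coumarin-Type Core

The compounds below may be only part of what the source reports. "The series", "measured", "known", "first", "only" and "open" are said of these compounds alone.

Measured so far:
- Compound 1, `O=c1cc(O)c2ccc(OCc3cccc(Br)c3)cc2o1`: 490 nM
- Compound 2, `CC(=O)COc1cc(=O)oc2cc(OCc3cccc(Cl)c3)ccc12`: 26.9 nM

Of the compounds shown here, two have been tested in an assay on isolated protein (strain Sprague-Dawley) for inhibition of Amine oxidase [flavin-containing] B (Rattus norvegicus), read by spectrophotometry, with a stated time of 5 min; on this read-out lower numbers stand for stronger inhibition and higher numbers for weaker inhibition. Compound 1 gives 490 nM in this assay. Compound 2 gives 26.9 nM in this assay, the lower of the two numbers, and the gap to compound 1 lies beyond the usual scatter, so compound 2 is the stronger inhibitor of the pair. The two compounds differ in more than one place, so no single change can be credited for that gap.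

Compound 3, `O=c1cc(Nc2ccccc2)c2ccc(OCc3cccc(Cl)c3)cc2o1`, has not yet been measured. It keeps the core and the halogenated benzyloxy side of compound 2 and differs from it in one place: anilino in place of 2-oxopropoxy on an aromatic carbon. For the measured compounds named here, no measured pair shows what such a change does on this core, so the expectation rests only on the position compound 2 holds.

Compound 3 is expected to give 90 nM in this assay, within a range of 15 nM to 500 nM. The expected step of a 3.3-fold higher number from compound 2 to compound 3 (0.52 log units; beyond the scatter) is a moderate move toward weaker inhibition, somewhat beyond the scatter, though the range allows for no change at all.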

Compound 3, half-maximal inhibitory concentration: 9770 nM
Estimate against measurement, compound 3: 110-fold (2.04 log units) below; measured number above the stated range.
By their numbers in this assay, from the lowest: compound 2; then compound 1; then compound 3.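

In this assay, putting anilino in place of 2-oxopropoxy on this aromatic carbon, opposite the ring oxygen, gives a 360-fold higher number from compound 2 to compound 3 (2.56 log units; beyond the scatter) and marks a large move toward weaker inhibition, the first sign from a single change that this position does not accept every group alike. The step cannot be divided among its parts: the change brings in a six-membered aromatic ring and a hydrogen-bond donor, swaps oxygen for nitrogen at the point of attachment, and removes the carbonyl of the ketone chain, all at once. No measurement shown here gives a reason for the drop.

Which of these parts accounts for the loss remains open, and a single pair cannot show whether the ring, the nitrogen link or the missing carbonyl matters most. On these data alone, the effect of a plain amine, a methoxy group, a benzyloxy group or a longer ketone chain on the same carbon, with the rest of compound 2 kept unchanged, also stays unknown, and such groups would help separate these parts.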